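This account rests on a few compounds, and the source may have more. Where it says the series, first, only, none or still open, it means among the compounds named here.

Measured so far in an assay for binding affinity to Alpha-1B adrenergic receptor (Homo sapiens); on this read-out higher numbers stand for weaker inhibition and lower numbers for stronger inhibition:
compound 1, `CN1CCC[C@@H]1Cn1nc(Cc2ccc(F)cc2)c2ccccc2c1=O`, 79.4 nM
compound 2, `CN1CCCCC(n2nc(Cc3ccc(Cl)cc3)c3ccccc3c2=O)C1`, 158 nM
compound 3, `COC(=O)c1ccc(Cc2nn(C[C@H]3CCCN3C)c(=O)c3ccccc23)cc1`, a limit of the assay, > 1990 nM

Compound 1 and compound 2 give numbers that lie within the usual scatter of one another, so nothing separates them. Compound 3 is different in kind: for compound 3 this assay reports only a limit, > 1990 nM, and not a number. Within the data shown here, the one step that joins two measured compounds in a single place is an at least 25-fold higher number from compound 1 to compound 3 (1.39 log units; beyond the scatter); it ends at a limit, (the limit of > 1990 nM in this assay, at which 1 of the 3 values shown sits), so its true size is unknown beyond being large.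

Compound 4, `CN1CCC[C@@H]1Cn1nc(CC2CCCCC2)c2ccccc2c1=O`, is not yet measured. It differs from compound 1 in one place: cyclohexyl in place of 4-fluorophenyl on a saturated chain carbon bound to an aromatic carbon. Among the measured compounds shown here, no measured step concerns this kind of change. The step from compound 1 to compound 3 alters what sits on the aromatic ring, whereas here the aromatic ring itself leaves and a cyclohexyl enters in its place, so that step gives only a distant hint that this part of the molecule is sensitive to change. On that slender basis a moderate loss is expected, a 3.1-fold higher number from compound 1 to compound 4 (0.50 log units; beyond the scatter), with wide uncertainty. The estimate for compound 4 in this assay is 250 nM, within 60 nM to 1000 nM.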

Compound 4, inhibition constant: > 1990 nM
Compound 4: only a limit was reported; the forecaster's own chance of this, stated with the estimate: 15%; middle value at least 7.9-fold (0.90 log units) away from the limit.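

In this assay, exchanging 4-fluorophenyl for cyclohexyl on a saturated chain carbon bound to an aromatic carbon gives an at least 25-fold higher number from compound 1 to compound 4 (1.39 log units; beyond the scatter). Among these compounds, until now, the only large step at this part of the molecule was a change of substituent on the aromatic ring, methoxycarbonyl in place of fluoro; here a six-membered ring of carbon only remains at the same place, and its being non-aromatic, together with the loss of the fluoro, is enough for a large step. As far as these compounds go, the value of compound 4 is a limit of the assay and not a number, so the true size of this step is unknown beyond being large, and compound 4 cannot be ranked against compound 3, which also stands at that limit: the limit of > 1990 nM in this assay, at which 2 of the 4 values shown sit.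

The compounds shown leave open whether the large step follows from losing the aromatic ring or from losing the fluoro, a question that a plain phenyl group at this place would separate. They also leave open how a pyridyl ring, or a longer chain carrying the 4-fluorophenyl, would read in this assay.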